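From propylsulfonyl to ethylsulfonyl on the shared core

The compounds below may be only part of what the source reports. "The series", "measured", "known", "first", "only" and "open" are said of these compounds alone.

Compound 2 `c1ccc2c(c1)CCC2c1ncc[nH]1` is the bare core. In a functional assay on CHO cells for agonist activity at Alpha-1B adrenergic receptor (Homo sapiens), read by FLIPR and calcium flux (a lower number here means that less compound is needed, a higher number that more compound is needed for the effect), compound 2 gives only the limit > 10000 nM. Compound 1 `CCCS(=O)(=O)Nc1cccc2c1CCC2c1ncc[nH]1` carries the (propylsulfonyl)amino group on an aromatic carbon. In this assay compound 1 likewise gives only the limit > 10000 nM. The step that the two limits leave unreadable from compound 1 to compound 2 gives no size since both values sit at the limit of > 10000 nM in this assay, at which 2 of the 2 values shown sit. Compound 3 `CCS(=O)(=O)Nc1cccc2c1CCC2c1ncc[nH]1` differs from compound 2 by (ethylsulfonyl)amino in place of hydrogen on an aromatic carbon. Within the data shown here, the one measured step bearing on this change offers no direction or size. Compound 3 is expected at 20000 nM (range 5000 nM to 100000 nM), most likely again as a limit. The step that the limit leaves unreadable from compound 2 to compound 3 is thus expected to remain hidden in this assay.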

Compound 3, half-maximal effective concentration: > 10000 nM
Compound 3 was reported as a limit; the forecaster's own chance of this, stated with the estimate: 85%; the middle value is on the limit's open side.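

No step can be read between compound 3 and either compound 1 or compound 2, since all three stop at the same limit: the limit of > 10000 nM in this assay, at which 3 of the 3 values shown sit.

The compounds shown leave open whether (ethylsulfonyl)amino or (propylsulfonyl)amino on the shared core changes the response in this assay at all.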